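The source may report more compounds than this note shows. Statements on the series, on what has been measured and on what is new or still open speak of the compounds shown alone.

For the measured compounds named here, in an ADME assay on L6 cells (Rattus norvegicus) for cytotoxicity (on this read-out higher numbers stand for weaker inhibition and lower numbers for stronger inhibition), compound 1 `COc1cc2c(cc1C(C)NCc1ccccc1)CCC(C)(C)O2` gives 15300 nM, while compound 2 `COc1cc2c(cc1C(C)NCCCc1ccccc1)CCC(C)(C)O2` gives 2630 nM, the lower of the two numbers so far. Compound 3 `COc1cc2c(cc1C(C)NCCCCc1ccccc1)CCC(C)(C)O2` has not yet been measured. Its difference from compound 2 is benzyl in place of phenyl on a saturated chain carbon, three bonds along the chain from an amine nitrogen, with benzyl in place of phenyl on a saturated chain carbon, three bonds along the chain from an amine nitrogen. Going by the values given here, one measured step bears on this change, a modest one that extended the same chain: a 5.8-fold lower number from compound 1 to compound 2 (0.76 log units; beyond the scatter). The new change is a smaller extension of that kind, so a further drop in this assay is expected, though a smaller one, lying near the edge of the scatter. On the strength of that single step, the expected move is a 2.0-fold lower number from compound 2 to compound 3 (0.31 log units; beyond the scatter). The estimate for compound 3 is 1300 nM, within an expected range of 500 nM to 3000 nM.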

Compound 3, half-maximal inhibitory concentration: 5280 nM
Compound 3: middle estimate off by 4.1-fold (0.61 log units), on the low side; the measured number lies above the stated range.
By their numbers in this assay, from the lowest: compounds 2 and 3 (each within the scatter of the next); then compound 1.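

In this assay, putting benzyl in place of phenyl on a saturated chain carbon, three bonds along the chain from an amine nitrogen, gives a 2.0-fold higher number from compound 2 to compound 3 (0.30 log units; within the scatter) and so leaves compound 2 and compound 3 level. The fall in the number that came with the first extension therefore does not carry on to the 3-phenylpropyl chain, and compound 3 goes against any steady trend with chain length. The gain over the shortest chain still holds, with a 2.9-fold lower number from compound 1 to compound 3 (0.46 log units; beyond the scatter) as the step across both extensions.

Going by these compounds, whether a still longer chain would keep the number level or let it rise remains open. So does the effect of an ether oxygen within the chain or a fluorine on the terminal phenyl ring. No measurement given here accounts for this levelling off.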